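A few compounds are considered here, and "the series" means these few. Any claim that something is new, unique, unknown or untested is made for them only; others in the source may bear on it.

Among the compounds with values here, in an ADME assay on Vero cells (Chlorocebus sabaeus) for cytotoxicity, read by MTT assay, with a stated time of 72 h (on this read-out higher numbers stand for an effect only at larger amounts of compound and lower numbers for an effect already at smaller amounts), compound 1 (`Cc1cccc(C(=O)Nc2nc(-c3ccccn3)cs2)c1`) gives 4100 nM, the higher of the two numbers so far, while compound 2 (`CC(=O)c1cccc(C(=O)Nc2nc(-c3ccccn3)cs2)c1`) gives 1500 nM. Within the data shown here, the only measured step is a 2.7-fold lower number from compound 1 to compound 2 (0.44 log units; beyond the scatter), with acetyl in place of methyl on an aromatic carbon. Compound 3 (`O=C(Nc1nc(-c2ccccn2)cs1)c1ccc(Br)cc1`) has not yet been measured. It has 4-bromophenyl in place of 3-methylphenyl on a carbonyl carbon, and the shared core stays the same: 4-bromophenyl in place of 3-methylphenyl on a carbonyl carbon.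

The measured step bears on this change only in part. Among the measured compounds shown here, it also alters the 3-methylphenyl group of compound 1, but it leaves the ring in place, and no measured compound carries a 4-bromophenyl group. With a single modest step as a guide, a small shift in this assay is expected for compound 3, leaning towards a lower number, and it may not clear the scatter. The expected change is a 1.5-fold lower number from compound 1 to compound 3 (0.17 log units; within the scatter). For compound 3 the estimated value is 2800 nM. The expected range for compound 3 runs from 1000 nM to 8000 nM.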

Compound 3, half-maximal effective concentration: 4700 nM
Compound 3: middle estimate off by 1.7-fold (0.22 log units), on the low side; the measured number falls inside the stated range.
By their numbers in this assay, from the lowest: compound 2; then compounds 1 and 3 (each within the scatter of the next).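

In this assay the exchange of the whole 3-methylphenyl group for 4-bromophenyl on the carbonyl carbon amounts to a 1.1-fold higher number from compound 1 to compound 3 (0.06 log units; within the scatter) and so gives no change that can be told from the scatter. This shows that a different substituted phenyl group can stand at this place on the shared core without moving the number, while the earlier step of a 2.7-fold lower number from compound 1 to compound 2 (0.44 log units; beyond the scatter) remains the only one here that clears the scatter. Nothing given here explains why the acetyl change registers and the 4-bromophenyl change does not.

The compounds shown leave open whether a phenyl group bearing an amine, a carboxylic acid or a longer chain on the same carbonyl carbon would shift the number in this assay or stay within the scatter of compound 1. They also leave open whether the step to compound 2 belongs to the acetyl group alone or would recur with an ester or an amide on the ring.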